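The source may hold more compounds than are shown below. What is called first, only, known or untested is meant among the compounds shown, and "the series" means these compounds.

Values in a functional assay on SW-620 cells (Homo sapiens) for inhibition, read by MTT assay, with a stated time of 72 h; on this read-out lower numbers stand for stronger inhibition and higher numbers for weaker inhibition:
- compound 1 `COc1cc(NC(C)CCCNC(=O)Nc2cccc(Cl)c2)c2ncccc2c1`: 26000 nM
- compound 2 `COc1cc(NC(C)CCCNC(=O)NNC(=O)Nc2ccc(Cl)cc2)c2ncccc2c1`: 48000 nM
- compound 3 `COc1cc(NC(C)CCCNC(=O)NNC(=O)Nc2cccc(F)c2)c2ncccc2c1`: 9500 nM

Compound 3 has the lowest number of the three, and its gaps to both others lie beyond the scatter. The next compound to be measured is compound 4 `COc1cc(NC(C)CCCNC(=O)Nc2ccc(C(F)(F)F)cc2)c2ncccc2c1`. Its change from compound 3 is this: 4-(trifluoromethyl)phenyl in place of ((3-fluorophenyl)carbamoyl)amino on an amide-type nitrogen. In words, 4-(trifluoromethyl)phenyl replaces ((3-fluorophenyl)carbamoyl)amino on an amide-type nitrogen.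

Compound 1 is the closest guide, since it also has a phenyl group directly on that nitrogen. The swap of its 3-chlorophenyl for the longer group gave a 2.7-fold lower number from compound 1 to compound 3 (0.44 log units; beyond the scatter). A similar swap gave a 1.8-fold higher number from compound 1 to compound 2 (0.27 log units; within the scatter), so the longer group does not always go with a lower number. The ring change alone gave a 5.1-fold lower number from compound 2 to compound 3 (0.70 log units; beyond the scatter). Among the compounds with values here, no measured compound carries the 4-(trifluoromethyl)phenyl group, so the forecast stays loose.

Removing the longer group should undo a modest step, and the expected change is a 2.1-fold higher number from compound 3 to compound 4 (0.32 log units; beyond the scatter) in this assay. The estimate for compound 4 is 20000 nM, with an expected range from 8000 nM to 50000 nM.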

Compound 4, half-maximal inhibitory concentration: 22000 nM
Compound 4: middle estimate off by 1.1-fold (0.04 log units), on the low side; the measured number falls inside the stated range.
By their numbers in this assay, from the lowest: compound 3; then compounds 4, 1 and 2 (each within the scatter of the next, the first and the last beyond it).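

In this assay, a 4-(trifluoromethyl)phenyl group placed directly on the amide-type nitrogen is within the scatter of the 3-chlorophenyl group at the same place (a 1.2-fold lower number from compound 1 to compound 4 (0.07 log units; within the scatter)), so these two directly attached rings cannot be told apart here. Removing the longer carbamoyl-containing group has no single direction: the number rises with one ring (a 2.3-fold higher number from compound 3 to compound 4 (0.36 log units; beyond the scatter)) and falls with the other (a 2.2-fold lower number from compound 2 to compound 4 (0.34 log units; beyond the scatter)), both steps beyond the scatter. The longer group therefore does not by itself set the number, and the result depends on what it carries. Nothing measured here explains these shifts.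

The compounds shown leave open whether 3-fluorophenyl attached directly to that nitrogen would match compound 3. They also leave open how an unsubstituted phenyl, or a ring bearing an amine or a carboxylic acid, would behave at this place.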